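This account rests on a few compounds, and the source may have more. Where it says the series, first, only, none or still open, it means among the compounds named here.

Compound 1 `Cc1ccc(S(=O)(=O)c2cnc3c(F)cccc3c2N2CCC(C)CC2)cc1` — 93%
Compound 2 `Cc1ccc(S(=O)(=O)c2cnc3cc(F)ccc3c2N2CCC(C)CC2)cc1Cl` — 93%

In an assay on isolated protein for displacement of a labelled ligand from metabotropic glutamate receptor 5 (Homo sapiens), with a stated time of 60 min, tested at 1 uM (on this read-out higher numbers stand for more inhibition at the one concentration tested (going by the name of the read-out) and lower numbers for less inhibition), compound 1 gives 93%, and compound 2 gives 93%, so compound 1 stands level with compound 2 within the scatter of the measurement. Compound 3 `CC1CCN(c2c(S(=O)(=O)c3ccc(C#N)cc3)cnc3c(F)cccc23)CC1` has not yet been measured. It differs from compound 1 in one place: cyano in place of methyl on an aromatic carbon. Going by the values given here, no measured pair shows this change, so the expected step in this assay rests only on the high reading of compound 1, which leaves little room above. A small downward step, or none beyond the scatter, is expected a number 8 percentage points lower from compound 1 to compound 3 (within the scatter). Compound 3 is therefore estimated at 85%, within 62% to 98%.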

Compound 3, a percentage reported as inhibition, at one concentration (the size of the read-out at that concentration, not a potency): 86%
For compound 3 the middle estimate is 1 percentage points below the measured one; the range from low to high includes it.
By their numbers in this assay, from the lowest: compounds 3, 1 and 2 (each within the scatter of the next).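

In this assay, going by these compounds alone, the change from 4-methylphenyl to 4-cyanophenyl gives a step of a number 7 percentage points lower from compound 1 to compound 3 (within the scatter) and is the first change read on this aromatic carbon, para to a large group. At this position, cyano, with its hydrogen-bond acceptor, can therefore stand in for methyl without a change beyond the scatter. Nothing here accounts for this result. On these data alone, whether an amine, a carboxylic acid or a longer chain on this carbon would give a similar reading stays open. A reading at one concentration also leaves any difference in potency between compound 1 and compound 3 unresolved.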